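From compound 1 to compound 3: one stereocentre defined

A few compounds are considered here, and "the series" means these few. Any claim that something is new, unique, unknown or untested is made for them only; others in the source may bear on it.

Compound 1 `CCC1=C(C(=O)OCC2CCCCC2)C(c2cccc(O)c2)NC(=O)N1`: > 10000 nM, a limit
Compound 2 `CCC1=C(C(=O)OCC2CCCCC2)C(c2ccc(C(=O)O)cc2)NC(=O)N1`: > 10000 nM, a limit

In an ADME assay on CEMx174 cells (Homo sapiens) for cytotoxicity (on this read-out lower numbers stand for higher toxicity in this test and higher numbers for lower toxicity in this test), compound 1 gives > 10000 nM, which is a limit and not a number. Compound 2 gives > 10000 nM, again a limit. Compound 1 thus has no exact position, and the record so far reads: the limit of > 10000 nM in this assay, at which 2 of the 2 values shown sit.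

Compound 3 `CCC1=C(C(=O)OCC2CCCCC2)[C@H](c2cccc(O)c2)NC(=O)N1` has not yet been measured in this assay. Its difference from compound 1 is this: the two compounds have the same atoms and bonds; at least one stereo element is drawn with a configuration in one of them and without one in the other: 1 of 1 stereo elements differ; a stereocentre at a saturated ring carbon is drawn without a configuration in compound 1 and S in compound 3. Within the data shown here, the only measured step, a step that the two limits leave unreadable from compound 1 to compound 2, has no readable size and concerns a different change, so it offers no guide. The expectation rests instead on compound 1, whose > 10000 nM is a limit.

Among the measured compounds shown here, the expected change is a step that the limit leaves unreadable from compound 1 to compound 3, with no step expected beyond the scatter. For compound 3 the estimate is 15000 nM, with an expected range of 8000 nM to 40000 nM.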

Compound 3, half-maximal cytotoxic concentration: > 10000 nM
Compound 3: only a limit was reported; the forecaster's own chance of this, stated with the estimate: 85%; the middle value lies beyond the limit too.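

In this assay, among these compounds, compound 3 gives > 10000 nM, which is a limit, so no step from compound 1 to compound 3 can be read. The compounds shown leave open whether the S configuration at the saturated ring carbon shifts the read-out at all, and where each compound truly stands: the limit of > 10000 nM in this assay, at which 3 of the 3 values shown sit.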